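The compounds below may be only part of what the source reports. "The series", "measured", "known", "first", "only" and "open" are said of these compounds alone.

Compound 1, `c1ccc(-c2cccc3c2CCC3c2ncc[nH]2)nc1`, gives > 10000 nM in a functional assay on CHO cells for agonist activity at Alpha-1B adrenergic receptor (Homo sapiens), read by FLIPR and calcium flux; on this read-out higher numbers stand for an effect only at larger amounts of compound and lower numbers for an effect already at smaller amounts; this is a limit of the assay, not a number.
Compound 2, `COc1cccc2c1CCC2c1ncc[nH]1`, gives > 10000 nM in this assay; this too is a limit of the assay.
Compound 3, `c1cncc(-c2cccc3c2CCC3c2ncc[nH]2)c1`, gives > 10000 nM in this assay; again this is a limit of the assay.

Compound 3 thus stands at the same limit as the other two measured compounds, and its place among them cannot be resolved, because all three sit at the limit of > 10000 nM in this assay, at which 3 of the 3 values shown sit. The step from compound 1 to compound 3 is a step that the two limits leave unreadable from compound 1 to compound 3, and the step from compound 2 to compound 3 is a step that the two limits leave unreadable from compound 2 to compound 3; neither can be read, and the step from compound 1 to compound 2, a step that the two limits leave unreadable from compound 1 to compound 2, is likewise unreadable.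

Compound 4, `c1cc(-c2cn[nH]c2)c2c(c1)C(c1ncc[nH]1)CC2`, has not yet been measured in this assay. It differs from compound 3 by 1H-pyrazol-4-yl in place of pyridin-3-yl on an aromatic carbon. Every measured step around compound 3 is hidden by the limit, so nothing in the data gives a direction or size for this change. Compound 4 is therefore expected to give 15000 nM, with a range from 4000 nM to 60000 nM, most likely reported as a limit once more. The step from compound 3 to compound 4 that this estimate implies is a step that the limit leaves unreadable from compound 3 to compound 4.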

Compound 4, half-maximal effective concentration: > 10000 nM
Compound 4: only a limit was reported; the forecaster's own chance of this, stated with the estimate: 75%; the middle value is on the limit's open side.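

Within the data shown here, no step from compound 1, compound 2 or compound 3 to compound 4 can be read in this assay, because all four compounds stand at one limit of the assay: the limit of > 10000 nM in this assay, at which 4 of the 4 values shown sit. The compounds shown leave open whether any of them has an effect within the assay's range, and how pyridin-2-yl, pyridin-3-yl, methoxy and 1H-pyrazol-4-yl rank against one another.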